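Swapping a phenyl for pyridin-3-yl on an amide nitrogen

The source may hold more compounds than are shown below. What is called first, only, known or untested is meant among the compounds shown, and "the series" means these compounds.

Of the compounds shown here, two have been measured in a physicochemical assay for lipophilicity, read by HPLC, in phosphate buffer, measured as chromatographic lipophilicity, at pH 7.4; on this read-out higher numbers stand for higher lipophilicity and lower numbers for lower lipophilicity. Compound 1 `Cc1cc(C)cc(NC(=O)COc2cc(C)nc3ccc(Cl)cc23)c1` gives 6.38. Compound 2 `COc1ccc2nc(C)cc(OCC(=O)Nc3ccccc3)c2c1` gives 4.28 in this assay, the lower of the two numbers, and its nearest neighbour, compound 1, sits higher by a gap that lies beyond the usual scatter. Compound 3 `COc1ccc2nc(C)cc(OCC(=O)Nc3cccnc3)c2c1` has not yet been measured. Compared with compound 2 it carries one change: pyridin-3-yl in place of phenyl on an amide-type nitrogen. Among the measured compounds shown here, no measured pair shows this exact change, so the expectation rests on compound 2 alone and on the change itself. The step from compound 2 to compound 3 is expected to be downward and clearly larger than the scatter, roughly a number 1.18 log units lower from compound 2 to compound 3 (beyond the scatter). Because compound 2 gives 4.28 in this assay, compound 3 is estimated at 3.1, with a likely range from 2.5 to 3.7.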

Compound 3, distribution coefficient: 2.46
For compound 3 the middle estimate is 0.64 log units above the measured one; measured number below the stated range.
By their numbers in this assay, from the lowest: compound 3; then compound 2; then compound 1.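

Among the compounds shown here, this is the first pair in the set that differs in only one place, so the effect of the group on the amide-type nitrogen can be read directly. In this assay, putting pyridin-3-yl in place of phenyl gives a number 1.82 log units lower from compound 2 to compound 3 (beyond the scatter), with no other change to the molecule. The two groups have the same number of heavy atoms, and the counted differences are one ring nitrogen in place of a carbon and one hydrogen-bond acceptor, yet no measurement shown explains the size of the step.

For the compounds shown here, with only this pair, it remains open whether the same swap would give a similar step on the core of compound 1. On these data alone, it is also open how pyridin-2-yl, pyridin-4-yl or a phenyl ring carrying an amine or a carboxylic acid would read at this position.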